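The compounds below may be only part of what the source reports. "The series", "measured", "known", "first", "only" and "open" are said of these compounds alone.

Three compounds share one core. Compound 1 `CN(C(=O)NC(=O)c1ccccc1F)c1nc(C(F)(F)F)c(C(=O)N/N=C/c2cc(C(F)(F)F)cc(C(F)(F)F)c2)s1` gives 4.98 ug/mL in a functional assay on HeLa cells (Homo sapiens) for inhibition, read by MTT assay, with a stated time of 72 h; a lower number here means a stronger inhibitor, a higher number a weaker inhibitor; compound 2 `CN(C(=O)NC(=O)c1cccc(C(F)(F)F)c1)c1nc(C(F)(F)F)c(C(=O)N/N=C/c2cc(C(F)(F)F)cc(C(F)(F)F)c2)s1` gives 5.34 ug/mL; compound 3 `CN(C(=O)NC(=O)c1ccc(C(F)(F)F)cc1)c1nc(C(F)(F)F)c(C(=O)N/N=C/c2cccc(C(F)(F)F)c2)s1` gives 6.2 ug/mL, the highest of the three numbers, yet within the scatter of both compound 1 and compound 2. Going by the values given here, the only measured single-place step, a 1.1-fold higher number from compound 1 to compound 2 (0.03 log units; within the scatter), lies within the scatter. Compound 4 `CN(C(=O)NC(=O)c1ccc(C(F)(F)F)cc1)c1nc(C(F)(F)F)c(C(=O)N/N=C/c2cc(C(F)(F)F)cc(C(F)(F)F)c2)s1` is reached by trifluoromethyl in place of hydrogen on an aromatic carbon on an aromatic carbon of a six-membered aromatic ring of carbon only, meta to a trifluoromethyl group. Among the compounds with values here, no measured step covers this change; compounds 1 and 2, which carry the same pair of groups on that ring, sit close to compound 3. The expected step of a 1.2-fold lower number from compound 3 to compound 4 (0.08 log units; within the scatter) is therefore none beyond the scatter. Compound 4 is estimated at 5.2 ug/mL, between 3 ug/mL and 9 ug/mL.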

Compound 4, half-maximal inhibitory concentration: 5.78 ug/mL
Compound 4: the middle estimate sits 1.1-fold (0.05 log units) below what was measured; low and high end bracket the measured number.
By their numbers in this assay, from the lowest: compounds 1, 2, 4 and 3 (each within the scatter of the next).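

In this assay the added trifluoromethyl, meta to a trifluoromethyl group, gives a 1.1-fold lower number from compound 3 to compound 4 (0.03 log units; within the scatter) and so leaves no readable difference at this position. Changing the group on the carbonyl carbon with this ring held fixed also shows none: 4-(trifluoromethyl)phenyl gives a 1.1-fold higher number from compound 2 to compound 4 (0.03 log units; within the scatter) in place of 3-(trifluoromethyl)phenyl and a 1.2-fold higher number from compound 1 to compound 4 (0.06 log units; within the scatter) in place of 2-fluorophenyl. No evidence on the cause of these small steps is available. Still open, from the compounds shown here alone, is whether an amine or a carboxylic acid on this aromatic carbon would give a step beyond the scatter.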